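Compound 4 swaps the benzyl on the ring nitrogen

A few compounds are considered here, and "the series" means these few. Any claim that something is new, unique, unknown or untested is made for them only; others in the source may bear on it.

Compound 1, `COc1ccc(-c2cnc3nc(N)nc(N4CCN(c5ccc(F)cc5)CC4)c3n2)cc1OC`: in a functional assay on cells (T-cell, Homo sapiens) for inhibition (a lower number here means a stronger inhibitor, a higher number a weaker inhibitor), compound 1 gives 100 nM.
Compound 2, `COc1ccc(-c2cnc3nc(N)nc(N4CCN(c5ccc(C)cc5)CC4)c3n2)cc1OC`: compound 2 gives 300 nM.
Compound 3, `COc1ccc(-c2cnc3nc(N)nc(N4CCN(Cc5c(Cl)cccc5Cl)CC4)c3n2)cc1OC`: compound 3 gives 7600 nM.

Among these three, compound 3 carries the highest number in this assay; its steps to both other compounds lie beyond the scatter, so it is the weakest inhibitor of the set. Compound 4, `COc1ccc(-c2cnc3nc(N)nc(N4CCN(C(=O)NCc5ccc(F)cc5)CC4)c3n2)cc1OC`, has not yet been measured. It differs from compound 3 at the amine nitrogen in the ring: (4-fluorobenzyl)carbamoyl in place of 2,6-dichlorobenzyl on an amine nitrogen in a ring.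

The measured steps that touch this position are a 76-fold higher number from compound 1 to compound 3 (1.88 log units; beyond the scatter) and a 25-fold higher number from compound 2 to compound 3 (1.40 log units; beyond the scatter), both large and both in the same direction; the smaller step of a 3.0-fold higher number from compound 1 to compound 2 (0.48 log units; beyond the scatter) concerns only the substituent on the aromatic ring. For the measured compounds named here, no measured pair covers a carbamoyl on this nitrogen, so the direction of the new step is not fixed by the data. Since compound 3 sits at the top of the range, the writer expects a lower number, as a guess rather than a deduction: the estimated step is a 3.8-fold lower number from compound 3 to compound 4 (0.58 log units; beyond the scatter). Compound 4 is therefore estimated at 2000 nM, within a wide range from 300 nM to 15000 nM.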

Compound 4, half-maximal inhibitory concentration: 37 nM
Beside the measured number, compound 4's estimate is 54-fold (1.73 log units) above it; measured number below the stated range.
By their numbers in this assay, from the lowest: compound 4; then compound 1; then compound 2; then compound 3.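

In this assay the amine nitrogen in the ring accepts a (4-fluorobenzyl)carbamoyl well: the change gives a 210-fold lower number from compound 3 to compound 4 (2.31 log units; beyond the scatter) and also improves on both directly attached aryl groups, with an 8.1-fold lower number from compound 2 to compound 4 (0.91 log units; beyond the scatter) and a 2.7-fold lower number from compound 1 to compound 4 (0.43 log units; beyond the scatter), which makes compound 4 the strongest inhibitor of the four. The earlier compounds shown here could have suggested that a benzyl unit on this nitrogen is costly, but compound 4 shows that a benzyl-bearing group can outperform the aryl groups once a carbamoyl carries it, although the change from compound 3 also replaces 2,6-dichloro with 4-fluoro on the aromatic ring, so the gain cannot be assigned to either part alone. The data offer no measured explanation for this gain.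

Going by these compounds, it remains open whether a plain 4-fluorobenzyl directly on this nitrogen, without the carbonyl, would keep any of this inhibition, and whether a 2,6-dichlorobenzyl carried on the same carbamoyl would match compound 4. Also open, on these data alone, is how a methyl on the carbamoyl nitrogen in place of the amide hydrogen, or an acetyl or a methanesulfonyl on the ring nitrogen, would fare.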